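Aryl sulfone cyanoguanidines: trifluoromethylphenyl replaces the bicyclic amine

This account rests on a few compounds, and the source may have more. Where it says the series, first, only, none or still open, it means among the compounds named here.

Among the measured compounds shown here, compound 3 `N#C/N=C(\NCc1ccc(S(=O)(=O)N2CC3CCC(C2)O3)cc1)Nc1ccncc1` gives 50 nM in a functional assay on A2780 cells (Homo sapiens) for antiproliferative activity, read by sulforhodamine B assay, with a stated time of 72 h (on this read-out higher numbers stand for weaker inhibition and lower numbers for stronger inhibition), the highest of the three numbers so far. Compound 2 `N#C/N=C(\NCc1ccc(S(=O)(=O)c2ccccc2)cc1)Nc1cccnc1` gives 30 nM, which sits within the scatter of compound 3. Compound 1 `N#C/N=C(\NCc1ccc(S(=O)(=O)c2ccccc2)cc1)Nc1ccncc1` gives 9.7 nM; the step of a 5.2-fold higher number from compound 1 to compound 3 (0.71 log units; beyond the scatter) lies beyond the scatter, as does a 3.1-fold higher number from compound 1 to compound 2 (0.49 log units; beyond the scatter).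

Compound 4 `N#C/N=C(\NCc1ccc(S(=O)(=O)c2cccc(C(F)(F)F)c2)cc1)Nc1ccncc1` differs from compound 3 in one place: a group of 10 heavy atoms (7 carbon, 3 fluorine; one six-membered aromatic ring of carbon only) in place of a group of 8 heavy atoms (6 carbon, 1 nitrogen, 1 oxygen; one five-membered non-aromatic ring with 1 hetero atom, one six-membered non-aromatic ring with 2 hetero atoms), on a sulfonyl sulfur. For the measured compounds named here, the only measured step that bears on the sulfonyl sulfur is a 5.2-fold higher number from compound 1 to compound 3 (0.71 log units; beyond the scatter), where a six-membered aromatic ring of carbon only goes with a clearly lower number than the group of 8 heavy atoms. Going by the values given here, compound 4 again carries an aromatic ring on the sulfonyl sulfur, now as 3-(trifluoromethyl)phenyl; no measured pair shows what the trifluoromethyl adds, so the expectation rests on compound 1 alone. Because compound 1 gives 9.7 nM, the number for compound 4 is expected to drop by about a 4.2-fold lower number from compound 3 to compound 4 (0.62 log units; beyond the scatter), back toward compound 1. The estimate for compound 4 is 12 nM, in the range 5 nM to 35 nM.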

Compound 4, half-maximal inhibitory concentration: 2.9 nM
The estimate for compound 4 lay 4.1-fold (0.62 log units) above the measured number; the measured number lies below the stated range.
By their numbers in this assay, from the lowest: compound 4; then compound 1; then compounds 2 and 3 (each within the scatter of the next).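

In this assay, trifluoromethyl in place of hydrogen on an aromatic carbon gives a 3.3-fold lower number from compound 1 to compound 4 (0.52 log units; beyond the scatter) and shows that the plain phenyl on the sulfonyl sulfur can be improved by substitution on its ring. Replacing the bicyclic amine with 3-(trifluoromethyl)phenyl at the same sulfur gives a 17-fold lower number from compound 3 to compound 4 (1.24 log units; beyond the scatter) and widens the separation between this substituted aryl group and the bicyclic amine. Nothing available accounts for either step.

On these data alone, whether the gain is specific to trifluoromethyl remains open, since a methyl, a chlorine or a methoxy group on the same phenyl ring would test that. As far as these compounds go, it is also open whether 3-(trifluoromethyl)phenyl gives a comparable step when the pyridin-3-yl group of compound 2 replaces pyridin-4-yl on the amine nitrogen.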